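Adding a chloro group to compound 3

The compounds below may be only part of what the source reports. "The series", "measured", "known", "first", "only" and "open" are said of these compounds alone.

Compound 1 `CCOC(=O)/C=C/c1cc(OC)ccc1OC(=O)c1nc(C)c(C)nc1C` gives 196000 nM
Compound 2 `Cc1nc(C)c(C(=O)Oc2ccc(Cl)cc2/C=C/C(=O)O)nc1C` gives 57200 nM
Compound 3 `CCOC(=O)/C=C/c1ccccc1OC(=O)c1nc(C)c(C)nc1C` gives 110000 nM

In a functional assay on a cell-free system (Platelet, plasma, Oryctolagus cuniculus) for inhibition, with a stated time of 5 min, at 37 degrees C (a higher number here means a weaker inhibitor, a lower number a stronger inhibitor), compound 3 gives 110000 nM and lies within the scatter of both compound 1 and compound 2, so it is not clearly separated from either. Compound 4 `CCOC(=O)/C=C/c1cc(Cl)ccc1OC(=O)c1nc(C)c(C)nc1C` differs from compound 3 by chloro in place of hydrogen on an aromatic carbon and nothing else. Among the compounds with values here, the one measured step of this kind, hydrogen in place of methoxy, is a 1.8-fold lower number from compound 1 to compound 3 (0.25 log units; within the scatter) and so stays within what repeat measurements would show. Within the data shown here, compound 2 also carries chloro, but as a free acid rather than an ethyl ester, so no measured step isolates chloro. The expected change is a 1.2-fold lower number from compound 3 to compound 4 (0.06 log units; within the scatter) and thus no shift beyond the scatter in this assay is anticipated. Compound 4 is estimated at 95000 nM with an expected range from 40000 nM to 220000 nM in this measurement.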

Compound 4, half-maximal inhibitory concentration: 67100 nM
For compound 4 the middle estimate is 1.4-fold (0.15 log units) above the measured one, within the range that was stated.
By their numbers in this assay, from the lowest: compounds 2, 4, 3 and 1 (each within the scatter of the next, the first and the last beyond it).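

In this assay, within the data shown here, chloro in place of hydrogen on this aromatic carbon gives a 1.6-fold lower number from compound 3 to compound 4 (0.21 log units; within the scatter) and so cannot be told apart from hydrogen, while chloro in place of methoxy on the same carbon gives a 2.9-fold lower number from compound 1 to compound 4 (0.47 log units; beyond the scatter) as the first single change here to pass the scatter, though only modestly. With chloro present, the ethyl ester against the free acid gives a 1.2-fold higher number from compound 2 to compound 4 (0.07 log units; within the scatter) and so makes no clear difference. No measurement here explains these numbers.

From the compounds shown here alone, whether a bromo group, a nitrile or an amine on this carbon would move the number clearly away from hydrogen stays open. So does whether a longer ester chain would matter.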